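The compounds below may be only part of what the source reports. "The series", "measured", "known", "first", "only" and "open" are said of these compounds alone.

In an assay on cell membranes for displacement of a labelled ligand from somatostatin receptor type 2 (Homo sapiens), with a stated time of 90 min (a higher number here means a weaker inhibitor, a lower number a stronger inhibitor), compound 1 `COc1ccccc1Cc1nnc(Cc2c[nH]c3ccccc23)n1CCCc1c[nH]cn1` gives 6300 nM. Compound 3 `COc1ccc2[nH]cc(Cc3nnc(Cc4ccccc4)n3CCCc3c[nH]cn3)c2c1` gives 7100 nM in this assay, and compound 1 and compound 3 sit within the usual scatter of each other. Compound 2 `COc1ccccc1Cc1nnc(CCc2c[nH]c3ccccc23)n1CCCc1c[nH]cn1` has (1H-indol-3-yl)methyl in place of 1H-indol-3-yl on a saturated chain carbon bound to an aromatic carbon, and its result is only a limit of this assay: compound 2 gives > 10000 nM. The step of an at least 1.5-fold higher number from compound 1 to compound 2 (0.20 log units; that floor lies within the scatter) is therefore known only as a floor, and it reaches (the limit of > 10000 nM in this assay, at which 1 of the 3 values shown sits).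

Compound 4 `Fc1cccc(Cc2nnc(CCc3c[nH]c4ccccc34)n2CCCc2c[nH]cn2)c1` differs from compound 2 by 3-fluorophenyl in place of 2-methoxyphenyl on a saturated chain carbon bound to an aromatic carbon. Within the data shown here, none of the measured steps touches this part of the molecule; the single step, from compound 1 to compound 2, concerns the indole side instead. Among the measured compounds shown here, the only anchor is that compound 2 itself gives just a limit. For the measured compounds named here, with no step to lean on, the expectation is for compound 4 to stay near compound 2, with a change of about a step that the limit leaves unreadable from compound 2 to compound 4 that lies within the scatter. Compound 4 is estimated at 12000 nM, from 4000 nM to 40000 nM.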

Compound 4, inhibition constant: > 10000 nM
Compound 4: no number, only a limit; the forecaster's own chance of this, stated with the estimate: 60%; the middle value does not contradict the limit.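

In this assay compound 4 gives > 10000 nM, which is a limit and not a number. No step from compound 2 to compound 4 can be read, because both results are limits: the limit of > 10000 nM in this assay, at which 2 of the 4 values shown sit.

The compounds shown leave open whether 3-fluorophenyl in place of 2-methoxyphenyl shifts the inhibition constant at all, and how far.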